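Shrinking an Aromatic Substituent in a Fatty Acid Receptor Series

This account rests on a few compounds, and the source may have more. Where it says the series, first, only, none or still open, it means among the compounds named here.

Three compounds have been measured in an assay on isolated protein for agonist activity at Free fatty acid receptor 1 (Homo sapiens); a lower number here means that less compound is needed, a higher number that more compound is needed for the effect:
compound 1 `CC#CC(CC(=O)O)c1ccc(OCc2ccn3cc(-c4ccc(C5CCCCC5)cc4)nc3c2)cc1`: 559 nM
compound 2 `CC#CC(CC(=O)O)c1ccc(OCc2ccn3cc(-c4ccc(C)cc4C)nc3c2)cc1`: 503 nM
compound 3 `CC#CC(CC(=O)O)c1ccc(OCc2ccn3cc(-c4ccc(C(C)C)cc4)nc3c2)cc1`: 615 nM

Compound 3 gives the highest of the three numbers, yet the steps of a 1.1-fold higher number from compound 1 to compound 3 (0.04 log units; within the scatter) and a 1.2-fold higher number from compound 2 to compound 3 (0.09 log units; within the scatter) both lie within the scatter, so compound 3 stands level with the other two.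

Compound 4 `CC#CC(CC(=O)O)c1ccc(OCc2ccn3cc(-c4ccc(C)cc4)nc3c2)cc1` differs from compound 3 by one change: methyl in place of isopropyl on an aromatic carbon. For the measured compounds named here, no measured step repeats this exact exchange. The nearest guides are the swaps between the three aryl groups already tried, a 1.1-fold lower number from compound 1 to compound 2 (0.05 log units; within the scatter), a 1.1-fold higher number from compound 1 to compound 3 (0.04 log units; within the scatter) and a 1.2-fold higher number from compound 2 to compound 3 (0.09 log units; within the scatter), none of which moves beyond the scatter, and compound 2 already carries methyl groups on its aryl ring without any shift. A step of about a 1.0-fold lower number from compound 3 to compound 4 (0.01 log units; within the scatter) is therefore expected, essentially none. Compound 4 is estimated at 600 nM, between 300 nM and 1200 nM.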

Compound 4, half-maximal effective concentration: 618 nM
Estimate against measurement, compound 4: 1.0-fold (0.01 log units) below, within the range that was stated.
By their numbers in this assay, from the lowest: compounds 2, 1, 3 and 4 (each within the scatter of the next).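

In this assay, shrinking isopropyl to methyl on an aromatic carbon para to a large group gives a 1.0-fold higher number from compound 3 to compound 4 (0.00 log units; within the scatter) and so this position has now held cyclohexyl, isopropyl and methyl with no step beyond the scatter. Methyl also stands level with cyclohexyl in a 1.1-fold higher number from compound 1 to compound 4 (0.04 log units; within the scatter) and the 4-methylphenyl group stands level with the 2,4-dimethylphenyl group in a 1.2-fold higher number from compound 2 to compound 4 (0.09 log units; within the scatter) so neither change separates these compounds. Still open, on these data alone, is whether an amine or a hydroxyl group at this position would move the number. Nothing available here bears on what lies behind this level result.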